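From compound 2 to a ring-opened analogue

A few compounds are considered here, and "the series" means these few. Any claim that something is new, unique, unknown or untested is made for them only; others in the source may bear on it.

Compound 2 `C=CC(=O)Nc1cccc(Nc2nc(Nc3ccc(OCC(=O)N4CCCC4C(=O)OC)cc3)ncc2Cl)c1` gives the only number shown in a functional assay on Raji cells (Homo sapiens) for antiproliferative activity, read by CCK-8 assay, with a stated time of 72 h (on this read-out lower numbers stand for stronger inhibition and higher numbers for weaker inhibition), at 6700 nM. Compound 1 `C=CC(=O)Nc1cccc(Nc2nc(Nc3ccc(OCC(=O)NCC(=O)O)cc3)ncc2Cl)c1` reaches only the limit of this assay, > 40000 nM. Among the compounds with values here, the single measured step, an at least 5.9-fold lower number from compound 1 to compound 2 (0.77 log units; beyond the scatter), is bounded on one side by the limit of > 40000 nM in this assay, at which 1 of the 2 values shown sits. Compound 3 `C=CC(=O)Nc1cccc(Nc2nc(Nc3ccc(OCC(=O)NC(C)C(=O)OC)cc3)ncc2Cl)c1` differs from compound 2 by (1-(methoxycarbonyl)ethyl)amino in place of 2-(methoxycarbonyl)pyrrolidin-1-yl on a carbonyl carbon. The methoxycarbonyl group of compound 2 remains while the ring opens, and only that part of the measured step bears on the change. The reviewer expects a 1.5-fold higher number from compound 2 to compound 3 (0.17 log units; within the scatter), a step within the scatter or slightly weaker. Her estimate for compound 3 is 10000 nM, ranging from 3000 nM to 40000 nM.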

Compound 3, half-maximal inhibitory concentration: 25200 nM
The estimate for compound 3 lay 2.5-fold (0.40 log units) below the measured number; the range from low to high includes it.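

With the methoxycarbonyl group kept, (1-(methoxycarbonyl)ethyl)amino in place of 2-(methoxycarbonyl)pyrrolidin-1-yl on a carbonyl carbon gives in this assay a 3.8-fold higher number from compound 2 to compound 3 (0.58 log units; beyond the scatter), so the ring itself counts at this position, which the earlier step could not show because ring and ester changed together there the limit of > 40000 nM in this assay, at which 1 of the 3 values shown sits.

That sentence breaks the colon rule, so the corrected text follows.

With the methoxycarbonyl group kept, (1-(methoxycarbonyl)ethyl)amino in place of 2-(methoxycarbonyl)pyrrolidin-1-yl on a carbonyl carbon gives in this assay a 3.8-fold higher number from compound 2 to compound 3 (0.58 log units; beyond the scatter). The ring thus counts at this position on its own, which the earlier step, with the ester changing as well, could not show. Going by these compounds, the remaining step, an at least 1.5-fold lower number from compound 1 to compound 3 (0.20 log units; that floor lies within the scatter), is only a floor, since it rests on a limit: the limit of > 40000 nM in this assay, at which 1 of the 3 values shown sits. Still open is how a carboxylic acid or a primary amine in place of the methoxycarbonyl group on the pyrrolidine ring would read here.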